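Adding a Methoxy Group to Compound 1

This account rests on a few compounds, and the source may have more. Where it says the series, first, only, none or still open, it means among the compounds named here.

Compound 1 `Cc1nnc(SCC(=O)N/N=c2/scc(-c3ccccc3)n2-c2ccccc2)s1` gives 61.8% in a functional assay on C6 cells (Rattus norvegicus) for cytotoxicity, read by MTT assay, with a stated time of 24 h, tested at 100 ug/mL; a higher number here means a weaker effect of the compound at the concentration tested, a lower number a stronger effect.
Compound 2 `Cn1cnnc1SCC(=O)N/N=c1/scc(-c2ccc(C#N)cc2)n1-c1ccccc1` gives 55.2% in this assay.
Compound 3 `Cn1nnnc1SCC(=O)N/N=c1/scc(-c2ccc(C#N)cc2)n1-c1ccccc1` gives 30.9% in this assay.

In this assay compound 1 has the highest of the three numbers, though compound 2 lies within the scatter of it; only compound 3 stands beyond. Among the compounds with values here, the single one-place step, a number 24.3 percentage points lower from compound 2 to compound 3 (beyond the scatter), concerns the ring on the sulfur and not the aryl ring. Compound 4 `COc1ccc(-c2cs/c(=N/NC(=O)CSc3nnc(C)s3)n2-c2ccccc2)cc1` differs from compound 1 by methoxy in place of hydrogen on an aromatic carbon. Within the data shown here, no measured step touches that position, so these data give no ground to expect a shift; compound 4 is therefore expected to stay close to compound 1, with a number 1.8 percentage points lower from compound 1 to compound 4 (within the scatter) expected to remain within the scatter. The estimate for compound 4 is 60%, expected between 40% and 80%.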

Compound 4, a percentage reported as activity, at one concentration (the size of the read-out at that concentration, not a potency): 25.9%
The estimate for compound 4 lay 34.1 percentage points above the measured number, and the stated range ends above it.
By their numbers in this assay, from the lowest: compounds 4 and 3 (each within the scatter of the next); then compounds 2 and 1 (each within the scatter of the next).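

Within the data shown here, until this result, no single step had touched the aromatic ring bearing this position. In this assay, the change from phenyl to 4-methoxyphenyl gives a number 35.9 percentage points lower from compound 1 to compound 4 (beyond the scatter), a stronger effect at the concentration tested, so a methoxy group on this aromatic carbon, para to a large group, clearly affects the read-out. Nothing available explains this step. As far as these compounds go, it remains open whether an amine, a hydroxyl or a longer ethoxy chain in the same place would act as methoxy does, and whether the step would hold with 1-methyl-1H-tetrazol-5-yl on the sulfur.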